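Cytotoxicity of a Piperazine Benzyl Series: the Carbamoyl Analogue

A few compounds are considered here, and "the series" means these few. Any claim that something is new, unique, unknown or untested is made for them only; others in the source may bear on it.

Measured compounds:
- compound 1 `CCOC(=O)c1cnc(N2CCN(Cc3cccc(F)c3)CC2)nc1Oc1c(C)cc(-c2ccc(C#N)cc2)cc1C`: > 125000 nM
- compound 2 `CCOC(=O)c1cnc(N2CCN(Cc3ccc([N+](=O)[O-])cc3)CC2)nc1Oc1c(C)cc(-c2ccc(C#N)cc2)cc1C`: > 125000 nM
- compound 3 `CCOC(=O)c1cnc(N2CCN(Cc3ccccc3[N+](=O)[O-])CC2)nc1Oc1c(C)cc(-c2ccc(C#N)cc2)cc1C`: >= 78700 nM

In an ADME assay on MT4 cells (Homo sapiens) for cytotoxicity, read by MTT assay, with a stated time of 4 days (a lower number here means that less compound is tolerated, a higher number that more compound is tolerated), compound 1 gives > 125000 nM, which is a limit of the assay rather than a measured number. In this assay compound 2 likewise gives > 125000 nM, also a limit. In this assay compound 3 gives >= 78700 nM, again a limit. All three therefore stand at or near the top of what this assay can report, as summarised by the limit of > 125000 nM in this assay, at which 2 of the 3 values shown sit, and by the limit of >= 78700 nM in this assay, at which 1 of the 3 values shown sits.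

The change now considered takes compound 1 to compound 4 `CCOC(=O)c1cnc(N2CCN(Cc3cccc(C(N)=O)c3)CC2)nc1Oc1c(C)cc(-c2ccc(C#N)cc2)cc1C`: carbamoyl in place of fluoro on an aromatic carbon. The steps already measured, a step that the two limits leave unreadable from compound 1 to compound 2, a step that the two limits leave unreadable from compound 1 to compound 3 and a step that the two limits leave unreadable from compound 2 to compound 3, cannot be read in size, since limits sit at both ends of each. They show only that exchanging one benzyl substituent for another has not pushed any compound below the range where this assay gives a number.

Within the data shown here, no measured step bears directly on the carbamoyl change. For compound 4 the expectation is therefore a result again at the limit, with a number no higher from compound 1 to compound 4 (the limit leaves the size open) expected to be no step beyond the scatter. Compound 4 is estimated at 125000 nM, within 50000 nM to 125000 nM.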

Compound 4, half-maximal cytotoxic concentration: 14800 nM
Beside the measured number, compound 4's estimate is 8.4-fold (0.93 log units) above it; measured number below the stated range.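

Among these compounds, the earlier steps among compound 1, compound 2 and compound 3 cannot be read, whereas carbamoyl on this aromatic carbon gives the first number that falls inside the range of this assay, with an at least 8.4-fold lower number from compound 1 to compound 4 (0.92 log units; beyond the scatter) for this single exchange. Among the compounds shown here, compound 4 also stands apart from both nitro compounds, with an at least 8.4-fold lower number from compound 2 to compound 4 (0.92 log units; beyond the scatter) and an at least 5.3-fold lower number from compound 3 to compound 4 (0.72 log units; beyond the scatter), so the substituent on the benzyl ring can change how much compound the cells tolerate, which the earlier compounds could not show. The steps starting from compound 1 and compound 2 are only minimum sizes because both of those compounds sit at a limit: the limit of > 125000 nM in this assay, at which 2 of the 4 values shown sit.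

The full size of the step starting from compound 3 stays open for the same reason: the limit of >= 78700 nM in this assay, at which 1 of the 4 values shown sits. It also remains open whether this lower number is particular to carbamoyl, since the compounds shown do not tell whether a carboxylic acid, an amine or a methyl ester in its place would give a number in this range as well.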